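This account rests on a few compounds, and the source may have more. Where it says the series, first, only, none or still open, it means among the compounds named here.

Compound 1, `NS(=O)(=O)c1ccc(/N=C2\NC(=O)/C(=C3/C(=O)Nc4ccccc43)S2)cc1`, in a functional assay on Caco-2 cells (Homo sapiens) for antiproliferative activity, read by MTT assay (on this read-out lower numbers stand for stronger inhibition and higher numbers for weaker inhibition), gives > 200000 nM, a limit of the assay rather than a number.
Compound 2, `NS(=O)(=O)c1ccc(/N=C2\NC(=O)/C(=C3/C(=O)Nc4ccc([N+](=O)[O-])cc43)S2)cc1`, gives 13800 nM.
Compound 3, `NS(=O)(=O)c1cccc(/N=C2\NC(=O)/C(=C3/C(=O)Nc4ccc([N+](=O)[O-])cc43)S2)c1`, gives 20600 nM.

Compound 2 holds the lowest of the two numbers shown; its nearest neighbour is compound 3, with a 1.5-fold higher number from compound 2 to compound 3 (0.17 log units; within the scatter), so the two cannot be ordered against each other. The third value, that of compound 1, sits at the limit of > 200000 nM in this assay, at which 1 of the 3 values shown sits, and is a limit only. Among the compounds with values here, the one large step in the set runs from compound 1 to compound 2, an at least 14-fold lower number from compound 1 to compound 2 (1.16 log units; beyond the scatter), the change being nitro in place of hydrogen on an aromatic carbon.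

Compound 4, `NS(=O)(=O)c1ccc(/N=C2\NC(=O)/C(=C3/C(=O)Nc4ccc(F)cc43)S2)cc1`, is not yet measured. It differs from compound 2 as follows: fluoro in place of nitro on an aromatic carbon. The step from compound 1 to compound 2 bears directly on this, since the group that enters there is the group that leaves here. With the nitro gone and only fluoro in its place, compound 4 is expected to move back toward the value of compound 1, an estimated 5.8-fold higher number from compound 2 to compound 4 (0.76 log units; beyond the scatter). For compound 4 the estimate in this assay is 80000 nM, with a range from 25000 nM to 250000 nM, and a fair chance that only a limit is reported.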

Compound 4, half-maximal inhibitory concentration: 59900 nM
Compound 4: middle estimate off by 1.3-fold (0.13 log units), on the high side; the range from low to high includes it.
By their numbers in this assay, from the lowest: compounds 2 and 3 (each within the scatter of the next); then compound 4. At a limit, above all of these: compound 1.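

In this assay, the position that carries nitro in compound 2 can now be read with a second group, and the two groups do not behave alike: fluoro in place of nitro gives a 4.3-fold higher number from compound 2 to compound 4 (0.64 log units; beyond the scatter), so the low number of compound 2 is only partly kept. Fluoro in place of hydrogen at the same position still counts, with an at least 3.3-fold lower number from compound 1 to compound 4 (0.52 log units; beyond the scatter), so among these three compounds the number falls from hydrogen to fluoro to nitro, and nitro is not the only group here that gives a number below the limit. The size of this last step remains a bound only, because compound 1 stands at a limit and not at a number: the limit of > 200000 nM in this assay, at which 1 of the 4 values shown sits.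

With only hydrogen, fluoro and nitro shown at this position, it remains open where an amine, a methoxy group, a nitrile or a chlorine would fall in this order, and whether the order would hold for any of them. From the compounds shown here alone, the change from 4-sulfamoylphenyl to 3-sulfamoylphenyl is seen only between compound 2 and compound 3, so how it would read with fluoro on the core also remains open.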